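A few compounds are considered here, and "the series" means these few. Any claim that something is new, unique, unknown or untested is made for them only; others in the source may bear on it.

Of the compounds shown here, three sharing one core have been measured in an in vitro functional assay on HEK285-7 cells for antagonist activity at prostaglandin D2 receptor 2 (Homo sapiens), read by BRET and beta-arrestin recruitment; a lower number here means a stronger inhibitor, a higher number a weaker inhibitor. Compound 1 `O=C(O)Cc1sc(C(c2ccc(F)cc2)c2ccc(F)cc2)nc1-c1cc(F)cc(F)c1` gives 340 nM. Compound 2 `NS(=O)(=O)c1ccc(-c2nc(C(c3ccc(F)cc3)c3ccc(F)cc3)sc2CC(=O)O)cc1` reaches only the limit of the assay, > 100000 nM, and so has no number. Compound 3 `Cc1cc(-c2nc(C(c3ccc(F)cc3)c3ccc(F)cc3)sc2CC(=O)O)ccn1` gives 53 nM, the lowest of the two numbers; its nearest neighbour is compound 1, and the step between them was a 6.4-fold lower number from compound 1 to compound 3 (0.81 log units; beyond the scatter). The other measured step, an at least 290-fold higher number from compound 1 to compound 2 (2.46 log units; beyond the scatter), shows how far the number can move in this assay when the group on the core is exchanged, as the assay limit of > 100000 nM in this assay, at which 1 of the 3 values shown sits, marks.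

Compound 4 `O=C(O)Cc1sc(C(c2ccc(F)cc2)c2ccc(F)cc2)nc1-c1ccnc(O)c1` differs from compound 3 by hydroxy in place of methyl on an aromatic carbon. Both measured steps replaced the whole group on an aromatic carbon of the shared core and both lay beyond the scatter, one modest and one large, while the present change is smaller in size. For compound 4 the number is therefore expected to rise rather than fall, by a step of a 15-fold higher number from compound 3 to compound 4 (1.18 log units; beyond the scatter). Compound 4 is estimated at 800 nM, with a range from 150 nM to 8000 nM.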

Compound 4, half-maximal inhibitory concentration: 890 nM
Compound 4: middle estimate off by 1.1-fold (0.05 log units), on the low side; the measured number falls inside the stated range.
By their numbers in this assay, from the lowest: compound 3; then compound 1; then compound 4. At a limit, above all of these: compound 2.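

In this assay, going by these compounds alone, the carbon next to the ring nitrogen proves sensitive on its own: with the rest of the group kept, exchanging a single heavy atom gives a 17-fold higher number from compound 3 to compound 4 (1.23 log units; beyond the scatter), a large step where the earlier steps replaced the whole group. A pyridine ring at this place therefore does not by itself give a lower number than 3,5-difluorophenyl: compound 3 lies below compound 1, while the other comparison goes against it, with a 2.6-fold higher number from compound 1 to compound 4 (0.42 log units; beyond the scatter). The remaining step, an at least 110-fold lower number from compound 2 to compound 4 (2.05 log units; beyond the scatter), starts from a limit rather than a number: the limit of > 100000 nM in this assay, at which 1 of the 4 values shown sits.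

The compounds shown leave open how a methoxy group, an amine or a chlorine atom on this same carbon would read. Such groups would help separate the effect of adding hydroxy from that of removing methyl.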